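Swapping the ether group from compound 3 to compound 4

A few compounds are considered here, and "the series" means these few. Any claim that something is new, unique, unknown or untested is made for them only; others in the source may bear on it.

In a functional assay on RS4-11 cells (Homo sapiens) for inhibition, read by CCK-8 assay, with a stated time of 48 h (on this read-out higher numbers stand for weaker inhibition and lower numbers for stronger inhibition), compound 3 (`Cc1cc(C)cc(NC(=O)NCCNS(=O)(=O)c2ccc(-c3ccccc3OCc3cccc(O)c3)s2)c1`) gives 5800 nM and compound 1 (`Cc1cc(C)cc(NC(=O)NCCNS(=O)(=O)c2ccc(-c3ccccc3Oc3ccc([N+](=O)[O-])c([N+](=O)[O-])c3)s2)c1`) gives 3600 nM, values within the scatter of each other. Compound 2 (`Cc1cc(C)cc(NC(=O)NCCNS(=O)(=O)c2ccc(-c3ccccc3OCc3ccccc3)s2)c1`) reads > 50000 nM, which is a limit of the assay (the limit of > 50000 nM in this assay, at which 1 of the 3 values shown sits).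

Compound 4 (`Cc1cc(C)cc(NC(=O)NCCNS(=O)(=O)c2ccc(-c3ccccc3Oc3ccc(N)cc3)s2)c1`) carries 4-aminophenyl in place of 3-hydroxybenzyl on an oxygen on an aromatic ring.

Among the compounds with values here, three measured steps bear on this change: an at least 13-fold higher number from compound 1 to compound 2 (1.14 log units; beyond the scatter) is large, an at least 8.6-fold lower number from compound 2 to compound 3 (0.93 log units; beyond the scatter) is at least modest, and a 1.6-fold higher number from compound 1 to compound 3 (0.21 log units; within the scatter) lies within the scatter. Compound 4 keeps a substituted ring on that oxygen, as compound 1 and compound 3 do, so no shift beyond the scatter is expected in this assay, and the expected step is a 1.2-fold lower number from compound 3 to compound 4 (0.06 log units; within the scatter). For compound 4 the estimated value is 5000 nM, with an expected range of 1500 nM to 20000 nM.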

Compound 4, half-maximal inhibitory concentration: > 20000 nM
Compound 4 ended at the assay's limit; the forecaster's own chance of this, stated with the estimate: 10%; at least 4.0-fold (0.60 log units) between middle value and limit.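

In this assay compound 4 stands at a limit, not a number: the limit of > 20000 nM in this assay, at which 1 of the 4 values shown sits. A substituted ring on that oxygen therefore does not by itself hold the read-out, as the change gives an at least 3.4-fold higher number from compound 3 to compound 4 (0.53 log units; beyond the scatter) and an at least 5.5-fold higher number from compound 1 to compound 4 (0.74 log units; beyond the scatter). The step between compound 2 and compound 4 cannot be read, as both values are limits.

Still open, from the compounds shown here alone, is whether this shift follows the amino group or the phenyl in place of benzyl, as compound 4 differs from compound 3 in both. A hydroxyphenyl or an aminobenzyl group on that oxygen would separate the two.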